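The source may report more compounds than this note shows. Statements on the series, on what has been measured and on what is new or still open speak of the compounds shown alone.

Working notes on the series.

Compound 1 `C#CCO/N=C1/C[C@@H](c2ccc(OC)cc2)Oc2cc(OC)c(CC=C(C)C)cc21` carries a small propargyl oxime on the shared core; in a functional assay on A549 cells (Homo sapiens) for inhibition, read by sulforhodamine B assay, with a stated time of 48 h, tested at 50 uM (a lower number here means less inhibition of growth, a higher number more inhibition of growth at the concentration tested), compound 1 gives 64%. Compound 3 `COc1cc2c(cc1CC=C(C)C)C(=O)C[C@@H](c1ccc(Oc3cccc([N+](=O)[O-])c3)cc1)O2`, with a ketone in place of the oxime and a nitrophenoxy group on the pendant aryl ring, gives in this assay a value of 37%. Compound 2 `COc1ccc([C@@H]2C/C(=N/OCc3cn(-c4ccc(C(=O)c5ccccc5)cc4)nn3)c3cc(CC=C(C)C)c(OC)cc3O2)cc1`, the triazolylmethyl oxime bearing a benzoylphenyl group, gives in this assay a value of 34%. On the three numbers shown compound 2 stands lowest, with compound 3 falling within the usual scatter of it and compound 1 lying beyond that scatter.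

Compound 4 `COc1ccc([C@@H]2C/C(=N/OCc3cn(-c4ccc(C#N)cc4)nn3)c3cc(CC=C(C)C)c(OC)cc3O2)cc1` is not yet measured. It differs from compound 2 in one place: cyano in place of benzoyl on an aromatic carbon. Among the compounds with values here, no step between measured compounds covers this exchange, so the expectation rests on the spread of the three values only. A step from compound 2 to compound 4 of modest size is expected in this assay, leaning toward more inhibition given that compound 1 with its smaller oxime substituent gives 64%, but a result within the scatter is equally possible; the expected step is a number 7 percentage points higher from compound 2 to compound 4 (within the scatter). Compound 4 is estimated to give 41% in this assay, with a range from 26% to 58%.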

Compound 4, percent growth inhibition at one concentration: 42%
The estimate for compound 4 lay 1 percentage points below the measured number; measured number inside the range.
By their numbers in this assay, from the lowest: compounds 2, 3 and 4 (each within the scatter of the next); then compound 1.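

In this assay, putting cyano in place of benzoyl on an aromatic carbon of a six-membered aromatic ring of carbon only, para to a large group, gives a number 8 percentage points higher from compound 2 to compound 4 (within the scatter). Within the data shown here, this is the first step read at this position, and it shows that a group with an aromatic ring of its own can give way to a much smaller group with no ring without the growth inhibition at the concentration tested moving beyond the scatter. Nothing at hand accounts for this outcome or tests it further.

The compounds shown leave open whether an amine, a carboxylic acid or a longer alkyl chain at this same place would also stay within the scatter of compound 2, since benzoyl and cyano are the only two groups compared here. They also leave open whether the same exchange would give a similar step on another oxime substituent or in another cell type, as this single pair offers one step in one assay at one concentration.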